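Working notes: replacing the carbonyl-linked aryl in compound 2

The source may hold more compounds than are shown below. What is called first, only, known or untested is meant among the compounds shown, and "the series" means these compounds.

Among the compounds with values here, compound 2 `CCCCCCCCS(=O)(=O)Nc1ccc(C(=O)c2ccccc2OC)cc1C(=O)O` gives 59200 nM in an assay on mitochondria (strain BALB/c) for inhibition of glycerol-3-phosphate acyltransferase 1, mitochondrial (Mus musculus), read by scintillation counting, with a stated time of 10 min (on this read-out higher numbers stand for weaker inhibition and lower numbers for stronger inhibition), the highest of the two numbers so far. Its nearest neighbour, compound 1 `CCCCCCCCS(=O)(=O)Nc1ccc(-c2ccc(CCCC)cc2)cc1C(=O)O`, gives 9000 nM in this assay. Within the data shown here, the one measured step, a 6.6-fold higher number from compound 1 to compound 2 (0.82 log units; beyond the scatter), went with (2-methoxyphenyl)carbonyl in place of 4-butylphenyl on an aromatic carbon. Compound 3 `CCCCCCCCS(=O)(=O)Nc1ccc(CCc2ccc(OC)cc2)cc1C(=O)O` is not yet measured. It differs from compound 2 by 2-(4-methoxyphenyl)ethyl in place of (2-methoxyphenyl)carbonyl on an aromatic carbon, meta to a carboxy group and para to a large group. Among the measured compounds shown here, only the step from compound 1 to compound 2 bears on this change: that step introduced the carbonyl-bearing group and raised the number, and compound 3 removes that group again, so a step back toward lower numbers in this assay is expected, though smaller than the measured one, since the incoming group is not 4-butylphenyl. Compound 3 is estimated at 15000 nM, range 5000 nM to 45000 nM. The expected step is a 3.9-fold lower number from compound 2 to compound 3 (0.60 log units; beyond the scatter).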

Compound 3, half-maximal inhibitory concentration: 26300 nM
For compound 3 the middle estimate is 1.8-fold (0.24 log units) below the measured one; measured number inside the range.
By their numbers in this assay, from the lowest: compound 1; then compound 3; then compound 2.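

In this assay the position tolerates loss of the carbonyl: 2-(4-methoxyphenyl)ethyl in place of (2-methoxyphenyl)carbonyl goes with a 2.3-fold lower number from compound 2 to compound 3 (0.35 log units; beyond the scatter), at an equal heavy-atom count. The same group in place of 4-butylphenyl goes with a 2.9-fold higher number from compound 1 to compound 3 (0.47 log units; beyond the scatter), so the directly attached 4-butylphenyl remains the group with the lowest number at this position, and the two-carbon link does not match it. No measurement among these data accounts for either step.

The change from compound 2 to compound 3 alters the link and the place of the methoxy group together, and the compounds shown do not separate these two contributions. Also open, on these data alone, is how a directly attached 4-methoxyphenyl, or an amide link carrying the same ring, would read here.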